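A Stereocentre Left Undrawn, at the Assay's Limit

The source may report more compounds than this note shows. Statements on the series, on what has been measured and on what is new or still open speak of the compounds shown alone.

In a functional assay on A549 cells (Homo sapiens) for cytotoxicity, read by MTT assay (a higher number here means a weaker inhibitor, a lower number a stronger inhibitor), compound 1, `CC1(C)CCc2c(C3CCc4ccc(O)cc4O3)ccc(O)c2O1`, gives > 100000 nM, which is a limit and not a number. Compound 2, `CC1(C)CCc2c([C@@H]3CCc4ccc(O)cc4O3)ccc(O)c2O1`, gives > 100000 nM, also a limit. Compound 3, `CC1(C)C=Cc2c([C@H]3CCc4ccc(O)cc4O3)ccc(O)c2O1`, gives > 100000 nM, again a limit, so it has no measured potency to compare.

Compound 4, `CC1(C)C=Cc2c(C3CCc4ccc(O)cc4O3)ccc(O)c2O1`, differs from compound 3 in one way: the two compounds have the same atoms and bonds; at least one stereo element is drawn with a configuration in one of them and without one in the other: 1 of 1 stereo elements differ; a stereocentre at a saturated ring carbon is drawn R in compound 3 and without a configuration in compound 4. Going by the values given here, the closest precedent is a step that the two limits leave unreadable from compound 1 to compound 2, where the atoms and bonds are also unchanged and only the drawing of a stereocentre at a saturated ring carbon differs. That step has no readable size, but both of its compounds stay at the limit, and so does compound 3. No step beyond the usual scatter is therefore expected in this assay, in either direction.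

The expected change is a number no higher from compound 3 to compound 4 (the limit leaves the size open). Compound 4 is estimated at about 100000 nM, with an expected range of 50000 nM to 200000 nM, and will most likely be reported only as a limit.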

Compound 4, half-maximal inhibitory concentration: > 100000 nM
Compound 4 was reported as a limit (the forecaster's own chance of this, stated with the estimate: 90%); the middle value sits exactly at the limit.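

No step can be read from compound 3 to compound 4, since each result is a limit and not a number. The compounds shown leave open whether the configuration at the saturated ring carbon affects potency in this assay; none of the four gives a measured number there.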